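The source may report more compounds than this note shows. Statements on the series, on what has been measured and on what is new or still open speak of the compounds shown alone.

Measured in a functional assay on S1 cells (Homo sapiens) for cytotoxicity, read by MTT assay, with a stated time of 72 h; a higher number here means a weaker inhibitor, a lower number a stronger inhibitor:
- Compound 1 `COc1ccc(/C=C/c2cc(C)no2)cc1OC`: > 100000 nM
- Compound 2 `COc1ccc(/C=C/C(=O)CC(C)=O)cc1OC`: 9300 nM

Compound 1 gives > 100000 nM, which is a limit and not a number. Its position is therefore (the limit of > 100000 nM in this assay, at which 1 of the 2 values shown sits).

The next compound, compound 3 `COc1ccc(/C=C/c2cc(C)no2)cc1`, differs from compound 1 as follows: hydrogen in place of methoxy on an aromatic carbon. This is hydrogen in place of methoxy on an aromatic carbon, ortho to a methoxy group, and the 3-methyl-1,2-oxazol-5-yl group stays.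

Going by the values given here, the only measured step is large: an at least 10-fold lower number from compound 1 to compound 2 (1.03 log units; beyond the scatter). It concerns a different place, where (2-oxopropyl)carbonyl takes the place of 3-methyl-1,2-oxazol-5-yl, and the methoxy groups are the same on both sides of it. Among the compounds with values here, no measured step therefore tests the loss of a methoxy group, and the data give no direction for this change. The large step gives no reason to expect a comparable gain here, so no step beyond the scatter is expected, and another limit reading in this assay is the likeliest outcome.

The estimated step is a number no higher from compound 1 to compound 3 (the limit leaves the size open).
Compound 3 is expected at 100000 nM, with an estimated range of 40000 nM to 300000 nM.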

Compound 3, half-maximal inhibitory concentration: 76400 nM
Beside the measured number, compound 3's estimate is 1.3-fold (0.12 log units) above it; the measured number falls inside the stated range.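

Going by these compounds alone, removing one methoxy group, with hydrogen in its place on an aromatic carbon ortho to a methoxy group, gives in this assay an at least 1.3-fold lower number from compound 1 to compound 3 (0.11 log units; that floor lies within the scatter), the first reading of this position. Compound 3 keeps the 3-methyl-1,2-oxazol-5-yl group and still gives a number rather than a limit, so that group does not by itself confine a compound to the limit of this assay. As far as these compounds go, the true size of the change stays unknown, and it cannot be called a gain beyond the scatter, because compound 1 is known only as a limit: the limit of > 100000 nM in this assay, at which 1 of the 3 values shown sits.

Still open, from the compounds shown here alone, is whether another group at this position, such as hydroxy, ethoxy or an amine, would move the number further than hydrogen does, and whether the remaining methoxy group matters in the same way. Also open, going by these compounds, is whether hydrogen in place of this methoxy group would act alike on compound 2, where (2-oxopropyl)carbonyl stands instead of the 3-methyl-1,2-oxazol-5-yl group and the starting value is a number rather than a limit.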